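This account rests on a few compounds, and the source may have more. Where it says the series, first, only, none or still open, it means among the compounds named here.

In a functional assay on V79 cells (Cricetulus griseus) for cytotoxicity, read by colony formation (a higher number here means a weaker inhibitor, a lower number a stronger inhibitor), compound 3 `CC1CN(c2c(F)cc3c(=O)c(C(=O)O)cn(C4CC4)c3c2C(F)(F)F)CC(C)N1` gives > 500 ug/mL, which is a limit of the assay and not a number. Compound 1 `O=C(O)c1cn(C2CC2)c2c(C(F)(F)F)c(N3CCCC3)c(F)cc2c1=O` gives 280 ug/mL, and compound 2 `NCC1CCN(c2c(F)cc3c(=O)c(C(=O)O)cn(C4CC4)c3c2C(F)(F)F)C1` gives 38 ug/mL. Compound 4 `NC1CCN(c2c(F)cc3c(=O)c(C(=O)O)cn(C4CC4)c3c2C(F)(F)F)CC1` is still unmeasured and differs from compound 3 by 4-aminopiperidin-1-yl in place of 3,5-dimethylpiperazin-1-yl on an aromatic carbon, with 4-aminopiperidin-1-yl in place of 3,5-dimethylpiperazin-1-yl. Within the data shown here, two measured steps bear most directly on this change: an at least 13-fold higher number from compound 2 to compound 3 (1.11 log units; beyond the scatter), and a 7.4-fold lower number from compound 1 to compound 2 (0.87 log units; beyond the scatter), where aminomethyl replaces hydrogen on a saturated ring carbon. Compound 4 also gains an amino group on its saturated ring, so it is expected to fall nearer compound 2 in this assay. A large move to a lower number is expected, an at least 8.3-fold lower number from compound 3 to compound 4 (0.92 log units; beyond the scatter). Compound 4 is estimated at 60 ug/mL, within an expected range of 15 ug/mL to 250 ug/mL.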

Compound 4, half-maximal inhibitory concentration: 20 ug/mL
Beside the measured number, compound 4's estimate is 3.0-fold (0.48 log units) above it, within the range that was stated.
By their numbers in this assay, from the lowest: compounds 4 and 2 (each within the scatter of the next); then compound 1. At a limit, above all of these: compound 3.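

In this assay, 4-aminopiperidin-1-yl and 3-(aminomethyl)pyrrolidin-1-yl cannot be told apart, with a 1.9-fold lower number from compound 2 to compound 4 (0.28 log units; within the scatter), so the low number seen for compound 2 is not confined to a single amine-bearing ring. The separation from the other two groups is wide, with a 14-fold lower number from compound 1 to compound 4 (1.15 log units; beyond the scatter) and an at least 25-fold lower number from compound 3 to compound 4 (1.39 log units; beyond the scatter). For compound 3 this rests on a limit of the assay and not a number: the limit of > 500 ug/mL in this assay, at which 1 of the 4 values shown sits.

The compounds shown leave open how a hydroxyl or dimethylamino group would read in place of the amino group on the piperidine ring. They also leave open whether a longer chain between that ring and the amine would shift the number.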